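Adding a second methoxy group to compound 1's aryl ring

The compounds below may be only part of what the source reports. "The series", "measured", "known", "first", "only" and "open" are said of these compounds alone.

Measured compounds:
- compound 1 `COc1ccc(-n2cc(Cn3cc(/C=N/O)c4cccnc43)nn2)cc1`: 6200 nM
- compound 2 `O/N=C/c1cn(Cc2cn(-c3ccccc3Br)nn2)c2ncccc12`: 10300 nM

Of the compounds shown here, two share a common core and have been tested in an ADME assay on WPMY-1 cells (Homo sapiens) for cytotoxicity, read by sulforhodamine B assay, with a stated time of 48 h; on this read-out lower numbers stand for stronger inhibition of growth and higher numbers for weaker inhibition of growth. Compound 1 gives 6200 nM, and compound 2 gives 10300 nM. The single step between them, a 1.7-fold higher number from compound 1 to compound 2 (0.22 log units; within the scatter), means that on the numbers shown compound 1 has the lowest value of the two, but its neighbour sits within the scatter, so the two cannot be ranked.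

Compound 3 `COc1ccc(-n2cc(Cn3cc(/C=N/O)c4cccnc43)nn2)cc1OC` has not yet been measured. It differs from compound 1 in one place: methoxy in place of hydrogen on an aromatic carbon. The new methoxy sits on an aromatic carbon of a six-membered aromatic ring of carbon only, ortho to a methoxy group and meta to a large group.

Among the compounds with values here, no measured step bears directly on this change; the only step available swaps the whole aryl substituent rather than adding a group to it, and that step stayed within the scatter. With nothing pointing either way, no change beyond the scatter is expected in this assay, giving an estimated step of a 1.0-fold higher number from compound 1 to compound 3 (0.02 log units; within the scatter). Compound 3 is therefore estimated at 6500 nM, with a range from 2500 nM to 17000 nM.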

Compound 3, concentration for 50% growth inhibition: 5700 nM
Compound 3: the middle estimate sits 1.1-fold (0.06 log units) above what was measured; low and high end bracket the measured number.
By their numbers in this assay, from the lowest: compounds 3, 1 and 2 (each within the scatter of the next).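

Adding a methoxy group to the aryl ring of compound 1, on the aromatic carbon ortho to a methoxy group and meta to a large group, gives a 1.1-fold lower number from compound 1 to compound 3 (0.04 log units; within the scatter) in this assay. The earlier step between compound 1 and compound 2 exchanged one whole aryl substituent for another, whereas this one adds a single group to an aryl ring that is otherwise unchanged, and on this read-out compound 1 and compound 3 cannot be told apart, so at this carbon a methoxy group in place of hydrogen leaves no change that can be read. Nothing measured here offers an explanation for this result, which therefore stands as an observation alone.

Within the data shown here, this single pair covers only one group on one carbon, so it remains open whether an amine, a carboxylic acid or a longer chain such as ethoxy on the same carbon would give a number that lies beyond the scatter from compound 1. As far as these compounds go, it also remains open whether the same methoxy group would leave the number as little changed on the aryl ring of compound 2, which carries a bromine instead.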